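Removing the last benzyl ether from a tetrol scaffold

A few compounds are considered here, and "the series" means these few. Any claim that something is new, unique, unknown or untested is made for them only; others in the source may bear on it.

The series rests on one shared core, shown in compound 1 `O[C@@H]1[C@@H](O)[C@H](Cc2ccccc2)O[C@H](COCc2ccccc2)[C@H]1O`, which carries three free hydroxy groups and a single benzyl ether. In a functional assay on HL-60 cells (Homo sapiens) for antiproliferative activity, read by MTT assay (a lower number here means a stronger inhibitor, a higher number a weaker inhibitor), compound 1 gives "not active" (no number reported), so no number is available for it and it cannot be placed on a scale against the others. Compound 2 `O[C@@H]1[C@@H](O)[C@H](Cc2ccccc2)O[C@H](COCc2ccccc2)[C@H]1OCc1ccccc1`, with one more benzyl ether, gives 26600 nM in this assay. Compound 3 `O[C@@H]1[C@@H](OCc2ccccc2)[C@H](OCc2ccccc2)[C@@H](COCc2ccccc2)O[C@@H]1Cc1ccccc1`, with benzyl on three oxygens, gives "not active" (no number reported) in this assay. Within the data shown here, no step between two measured compounds can be worked out from these entries.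

Compound 4 `OC[C@H]1O[C@@H](Cc2ccccc2)[C@H](O)[C@@H](O)[C@@H]1O` is the point reached when the remaining benzyl ether of compound 1 is opened: hydrogen in place of benzyl on an oxygen on a saturated carbon. The change runs away from the benzylated end of the series, where compound 2 already sits weakly and compound 3 reports nothing. Compound 1 gives no number, so the size of the step in this assay cannot be foreseen beyond saying that no gain is expected. Compound 4 is therefore expected to give about 100000 nM, within a range of 30000 nM to 300000 nM, and most likely only a limit.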

Compound 4, half-maximal inhibitory concentration: "not active" (no number reported)
Nothing numeric was reported for compound 4, so the estimate cannot be set against anything.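

Among these compounds, compound 1 and compound 4 both give no number in this assay, so no step from benzyloxy to hydroxy can be read between them. Nothing shown bears on a cause for this result. The compounds shown leave open how benzyl ethers on the shared core relate to antiproliferative activity.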